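A few compounds are considered here, and "the series" means these few. Any claim that something is new, unique, unknown or untested is made for them only; others in the source may bear on it.

Compound 1 `CCN(Cc1ccc(OC)cc1)C(=O)c1nc(-c2ccccc2)c2ccccc2n1`: 2.77 nM
Compound 2 `CCOC(=O)c1ccc(CN(CC)C(=O)c2nc(-c3ccccc3)c3ccccc3n2)cc1`: 3.65 nM

In an assay on cell membranes from kidney for displacement of a labelled ligand from Translocator protein (Rattus norvegicus) (a lower number here means a stronger inhibitor, a higher number a weaker inhibitor), compound 1 gives 2.77 nM and compound 2 gives 3.65 nM. Compound 2 thus holds the higher of the two numbers, although a 1.3-fold higher number from compound 1 to compound 2 (0.12 log units; within the scatter). Compound 3 `CCN(Cc1ccc(C(=O)O)cc1)C(=O)c1nc(-c2ccccc2)c2ccccc2n1` differs from compound 2 by hydrogen in place of ethyl on an oxygen next to a carbonyl group. Among the measured compounds shown here, no measured step removes this ethyl; the only step touching this part of the molecule, a 1.3-fold higher number from compound 1 to compound 2 (0.12 log units; within the scatter), was small. The expectation for compound 3 is therefore uncertain and leans toward a weaker inhibitor, an 11-fold higher number from compound 2 to compound 3 (1.04 log units; beyond the scatter), with an estimated 40 nM (5 nM to 400 nM).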

Compound 3, inhibition constant: 719 nM
Compound 3: the middle estimate sits 18-fold (1.25 log units) below what was measured; the whole stated range lies below it.
By their numbers in this assay, from the lowest: compounds 1 and 2 (each within the scatter of the next); then compound 3.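

Compound 1 and compound 2 suggested that this end of the molecule accepts change, but that does not extend to the carboxy group. In this assay, hydrogen in place of ethyl on the oxygen next to a carbonyl group gives a 200-fold higher number from compound 2 to compound 3 (2.29 log units; beyond the scatter), and carboxy in place of methoxy gives a 260-fold higher number from compound 1 to compound 3 (2.41 log units; beyond the scatter). No measurement at hand explains this loss.

Still open, on these data alone, is how a primary amide or an amine at this place would read, and thus whether the loss is specific to the carboxy group.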